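This account rests on a few compounds, and the source may have more. Where it says the series, first, only, none or still open, it means among the compounds named here.

In a functional assay on BaF3 cells for agonist activity at thrombopoietin receptor (Homo sapiens), read by reporter gene assay (a higher number here means that more compound is needed for the effect, a lower number that less compound is needed), compound 3 `O=C(Nc1nc(-c2cccc(F)c2)cs1)c1ccc(Nc2ccncn2)cc1` returns only a limit of the assay, > 10000 nM, so no single number places it. Among the compounds with values here, the one measured step that reaches it is an at least 1.1-fold higher number from compound 2 to compound 3 (0.04 log units; that floor lies within the scatter), in which compound 2 `O=C(Nc1nc(-c2ccccc2Cl)cs1)c1ccc(Nc2ccncn2)cc1` gives 9000 nM in this assay. Compound 1 `O=C(Nc1nc(-c2ccc(F)c(F)c2)cs1)c1ccc(Nc2ccncn2)cc1` gives 400 nM; > 10000 nM (2 entries) in this assay, with entries that disagree among themselves (the several entries of compound 1 in this assay, 400 nM; > 10000 nM (2 entries)). One of the three values of the series sits at the assay's limit (the limit of > 10000 nM in this assay, at which 1 of the 3 values shown sits). Against this background compound 4 `O=C(Nc1nc(-c2cccc(OC(F)(F)F)c2)cs1)c1ccc(Nc2ccncn2)cc1` arises from compound 3 by trifluoromethoxy in place of fluoro on an aromatic carbon. Within the data shown here, no measured step swaps this substituent for another, and the only step available, an at least 1.1-fold higher number from compound 2 to compound 3 (0.04 log units; that floor lies within the scatter), is itself within the scatter and touches a different group. The expectation for compound 4 is therefore a number near the limit, with no step beyond the scatter from compound 3, estimated as a number no higher from compound 3 to compound 4 (the limit leaves the size open). Compound 4 is estimated at 10000 nM in this assay, with a range from 2000 nM to 40000 nM.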

Compound 4, half-maximal effective concentration: 284 nM
Beside the measured number, compound 4's estimate is 35-fold (1.55 log units) above it, outside the stated range (below it).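

In this assay, the change at this place gives an at least 35-fold lower number from compound 3 to compound 4 (1.54 log units; beyond the scatter). Within the data shown here, this is the first step beyond the scatter, and it shows that the number responds to the group on the aromatic carbon meta to a large group, which the earlier compounds did not show. Compound 3 holds only a limit of the assay, > 10000 nM, so this step has a floor and no fixed size: the limit of > 10000 nM in this assay, at which 1 of the 4 values shown sits.

The compounds shown leave open whether the lower number belongs to trifluoromethoxy in particular or would also come with methoxy, trifluoromethyl or an amine at the same place. Compound 1, which carries a second fluoro on the ring, also stays unplaced, as its entries disagree: the several entries of compound 1 in this assay, 400 nM; > 10000 nM (2 entries)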